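The source may hold more compounds than are shown below. What is called first, only, known or untested is meant among the compounds shown, and "the series" means these compounds.

Measured compounds:
compound 1 `O=C(Nc1ccc(C(F)(F)F)cc1)N1CCN(c2ccccn2)CC1`, 1220 nM;
compound 2 `CC1CN(c2ncccc2C(F)(F)F)CCN1C(=O)Nc1ccc(C(F)(F)F)cc1`, 64 nM.

Among the compounds with values here, in an assay on isolated protein for inhibition of transient receptor potential cation channel subfamily V member 1 (Homo sapiens) (a lower number here means a stronger inhibitor, a higher number a weaker inhibitor), compound 2 gives 64 nM, the lower of the two numbers known, while compound 1 gives 1220 nM, and the gap between them is beyond the usual scatter. Compound 3 `CC1CN(c2ncccc2C(F)(F)F)CC(C)N1C(=O)Nc1ccc(C(F)(F)F)cc1` differs from compound 2 by methyl in place of hydrogen on a saturated ring carbon, a second methyl on the shared core. Within the data shown here, no comparable step is known, so the direction is open; the step from compound 2 to compound 3 is expected to be small, a 1.3-fold higher number from compound 2 to compound 3 (0.10 log units; within the scatter), within or near the scatter. Compound 3 is therefore estimated at 80 nM, in a range from 20 nM to 320 nM.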

Compound 3, half-maximal inhibitory concentration: 2450 nM
Compound 3: middle estimate off by 31-fold (1.49 log units), on the low side; the whole stated range lies below it.
By their numbers in this assay, from the lowest: compound 2; then compounds 1 and 3 (each within the scatter of the next).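

In this assay, putting methyl in place of hydrogen on a saturated ring carbon, next to the ring nitrogen, gives a 38-fold higher number from compound 2 to compound 3 (1.58 log units; beyond the scatter), so compound 3 is a much weaker inhibitor. This is the first single-place change among these compounds, and it shows that one added carbon at this position can matter greatly. Nothing available bears on why the number rises. On these data alone, whether a fluorine, a hydroxyl or an ethyl at this carbon would weaken inhibition as much remains open.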